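Removing a ring methyl from the shared core

A few compounds are considered here, and "the series" means these few. Any claim that something is new, unique, unknown or untested is made for them only; others in the source may bear on it.

Compound 1 `O=c1[nH]c2ccccc2cc1-c1nc2cc(F)ccc2[nH]1`, compound 2 `Cc1ccc2[nH]c(=O)c(-c3nc4cc(C)c(C)cc4[nH]3)cc2c1` and compound 3 `Cc1ccc2[nH]c(=O)c(-c3nc4cc(F)ccc4[nH]3)cc2c1` were run in a functional assay on BEL-7404 cells for cytotoxicity against BEL-7404 tumor cell line (Homo sapiens), read by MTT assay, with a stated time of 48 h; on this read-out lower numbers stand for stronger inhibition and higher numbers for weaker inhibition. Compound 1 gives 27500 nM in this assay. For compound 2 this assay reports only a limit, > 100000 nM. For compound 3 this assay likewise reports only a limit, > 100000 nM; this is the limit of > 100000 nM in this assay, at which 2 of the 3 values shown sit. Among the compounds with values here, the one single-point step measured is hydrogen in place of methyl on an aromatic carbon, which gives an at least 3.6-fold lower number from compound 3 to compound 1 (0.56 log units; beyond the scatter). The difference between the core of compound 2 and the core of compound 3 is not broken down here.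

Compound 4 `Cc1cc2nc(-c3cc4ccccc4[nH]c3=O)[nH]c2cc1C` is not yet measured. It differs from compound 2 by hydrogen in place of methyl on an aromatic carbon, the same change as that made from compound 3 to compound 1, at the same place. Resting on compound 1 reaching 27500 nM after that change, the expected step for compound 4 is an at least 2.0-fold lower number from compound 2 to compound 4 (0.30 log units; that floor lies within the scatter), to be set beside the measured at least 3.6-fold lower number from compound 3 to compound 1 (0.56 log units; beyond the scatter). On that basis compound 4 is expected to give about 50000 nM in this assay, with an estimated range from 15000 nM to 150000 nM, though a limit-only result remains possible.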

Compound 4, half-maximal inhibitory concentration: > 100000 nM
Compound 4: only a limit was reported (the forecaster's own chance of this, stated with the estimate: 40%); at least 2.0-fold (0.30 log units) between middle value and limit.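

In this assay compound 4 gives only a limit, > 100000 nM, and compound 2 is likewise reported only as a limit, so the step between these two compounds cannot be read. The compounds shown leave open whether the change from compound 3 to compound 1 carries over to compound 2 and compound 4, with the read-out stopping here: the limit of > 100000 nM in this assay, at which 3 of the 4 values shown sit.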